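The compounds below may be only part of what the source reports. "The series", "measured", "known", "first", "only" and "open" are said of these compounds alone.

Measured compounds:
compound 1 `C[C@@H]1CCCN1c1c(C#N)c2c(N)nc(Nc3cn(C)nc3C(F)(F)F)nc2n1C` gives 508 nM
compound 2 `C[C@@H]1CCCN1c1c(C#N)c2c(N)ncnc2n1C` gives 15 nM

In an assay on isolated protein for inhibition of Leucine-rich repeat serine/threonine-protein kinase 2 (Homo sapiens), read by TR-FRET and LanthaScreen, with stated times of 50 min and 30 min, in the presence of a further agent that is not named here (on this read-out higher numbers stand for weaker inhibition and lower numbers for stronger inhibition), compound 2 has the lowest number of the two; compound 1 is the nearest, and its number is higher by a margin that lies beyond the usual scatter. Compound 3 `C[C@@H]1CCCN1c1c(C#N)c2c(N)nc(Nc3cnn(C)c3)nc2n1C` has not yet been measured. It differs from compound 2 in one place: (1-methyl-1H-pyrazol-4-yl)amino in place of hydrogen on an aromatic carbon. Compound 1 carries a related group at the same place, with an extra trifluoromethyl on the five-membered ring, and there the larger group goes with a much weaker result than compound 2 shows. Compound 3 is therefore expected to sit somewhere between those two, most likely weaker than compound 2 but not as weak as compound 1, so the expected step of a 6.7-fold higher number from compound 2 to compound 3 (0.82 log units; beyond the scatter) is towards a higher number and beyond the scatter. The estimate for compound 3 is 100 nM, within a range of 25 nM to 400 nM.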

Compound 3, half-maximal inhibitory concentration: 6 nM
For compound 3 the middle estimate is 17-fold (1.22 log units) above the measured one; measured number below the stated range.
By their numbers in this assay, from the lowest: compound 3; then compound 2; then compound 1.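

In this assay, the aromatic carbon between two ring nitrogen atoms accepts a large addition without loss: a 2.5-fold lower number from compound 2 to compound 3 (0.40 log units; beyond the scatter), so the weak result of compound 1 does not mean that any substituted amino group at this place weakens inhibition. The weakness instead goes with the trifluoromethyl on the five-membered ring, since hydrogen in its place gives an 85-fold lower number from compound 1 to compound 3 (1.93 log units; beyond the scatter), a far larger change than the one produced by adding the whole (1-methyl-1H-pyrazol-4-yl)amino group. Nothing available here explains why either change has the size it has.

As far as these compounds go, it remains open whether the gain needs the five-membered ring at all, which a plain methylamino group at the same carbon would test. A methyl or a chlorine in place of the trifluoromethyl would show whether smaller groups there are also poorly accepted.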